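The compounds below may be only part of what the source reports. "The series", "measured", "known", "first", "only" and "open" are said of these compounds alone.

Working notes on the shared core of compound 1 `Fc1ccc2nc(-c3ccccc3)nc(Nc3ccccc3)c2c1`. In a functional assay on MCF7 cells (Homo sapiens) for cytotoxicity, read by MTT assay, with a stated time of 48 h (a lower number here means a stronger inhibitor, a higher number a weaker inhibitor), compound 1 gives only a limit, > 50000 nM. Compound 2 `Fc1cccc(-c2nc(Nc3cccc(Cl)c3)c3cc(F)ccc3n2)c1` in this assay likewise returns a limit, > 50000 nM. Compound 3 `Fc1cccc(-c2nc(Nc3ccccc3Br)c3cc(F)ccc3n2)c1` in this assay also gives a limit, > 50000 nM. Among the measured compounds shown here, the one comparable step in the set, a step that the two limits leave unreadable from compound 2 to compound 3, cannot be sized, because of the limit of > 50000 nM in this assay, at which 3 of the 3 values shown sit. Compound 2 therefore stands at the limit, and no ranking among the measured compounds can be drawn.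

Compound 4 `Nc1cccc(Nc2nc(-c3cccc(F)c3)nc3ccc(F)cc23)c1` differs from compound 2 by a single change: amino in place of chloro on an aromatic carbon. For the measured compounds named here, no measured step speaks to this change, since the one step recorded is itself unreadable. Given that compound 2 gives only the limit > 50000 nM, the estimated step that the limit leaves unreadable from compound 2 to compound 4 in this assay is expected to stay unreadable rather than to show a direction. Compound 4 is accordingly estimated at 60000 nM in this assay, with a range from 12000 nM to 300000 nM, and most likely reported again as a limit.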

Compound 4, half-maximal inhibitory concentration: > 50000 nM
Compound 4: no number, only a limit; the forecaster's own chance of this, stated with the estimate: 75%; the middle value does not contradict the limit.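

Compound 4 in this assay gives > 50000 nM, again a limit and not a number. The steps linking compound 4 with compound 2 and compound 3 cannot be read, because all values stop at the same point: the limit of > 50000 nM in this assay, at which 4 of the 4 values shown sit.

The compounds shown leave open which change to the shared core, if any, would give a measurable value in this assay.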